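Swapping an Ester Side Chain for an Amine

The compounds below may be only part of what the source reports. "The series", "measured", "known", "first", "only" and "open" are said of these compounds alone.

In a functional assay on MCF7 cells (Homo sapiens) for cytotoxicity, read by MTT assay, with a stated time of 72 h (a lower number here means a stronger inhibitor, a higher number a weaker inhibitor), compound 2 `COC(=O)CNc1c(C(=O)NCc2ccc(F)cc2)nc(Br)c2cccnc12` gives only the limit of > 10000 nM, which is not a number. Compound 1 `NCCCNc1c(C(=O)NCc2ccc(F)cc2)ncc2cccnc12` also gives only the limit of > 10000 nM. This agrees with the limit of > 10000 nM in this assay, at which 2 of the 2 values shown sit. Compound 3 `NCCCNc1c(C(=O)NCc2ccc(F)cc2)nc(Br)c2cccnc12` differs from compound 2 by 2-aminoethyl in place of methoxycarbonyl on a saturated chain carbon bound to a nitrogen on an aromatic ring. Within the data shown here, no step between two measured compounds is available, so the effect of this change cannot be read from the data, and both measured compounds sit at the limit. The expected step is a step that the limit leaves unreadable from compound 2 to compound 3, none beyond the scatter. Compound 3 is therefore estimated at 20000 nM, between 7000 nM and 60000 nM.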

Compound 3, half-maximal inhibitory concentration: 6000 nM
Estimate against measurement, compound 3: 3.3-fold (0.52 log units) above, outside the stated range (below it).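

In this assay, among these compounds, compound 3 gives the first value here that is a number rather than a limit, so the series can be read at this position. The change to 2-aminoethyl on the saturated chain carbon gives an at least 1.6-fold lower number from compound 2 to compound 3 (0.22 log units; that floor lies within the scatter), and bromo in place of hydrogen on an aromatic carbon gives an at least 1.6-fold lower number from compound 1 to compound 3 (0.22 log units; that floor lies within the scatter). Each step is only a floor, and the true size stays unknown because the starting compounds sit at a limit: the limit of > 10000 nM in this assay, at which 2 of the 3 values shown sit.

The compounds shown leave open how a carboxylic acid or a longer chain ending in an amine would read at this place. They also leave open whether the amine or the chain length matters more.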